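This account rests on a few compounds, and the source may have more. Where it says the series, first, only, none or still open, it means among the compounds named here.

Compound 1 `CC/C=C\C[C@H]1C(=O)C=C[C@H]1CC(=O)OCCCCC` gives 25000 nM
Compound 2 `CC/C=C\C[C@H]1C(=O)C=C[C@H]1CC(=O)OCCOC` gives 27000 nM
Compound 3 `CC/C=C\C[C@H]1C(=O)C=C[C@H]1CC(=O)OCCOCCOC` gives 33000 nM

In a functional assay on RAW264.7 cells (Mus musculus) for inhibition, read by ELISA, with a stated time of 24 h (on this read-out higher numbers stand for an effect only at larger amounts of compound and lower numbers for an effect already at smaller amounts), compound 3 (33000 nM) lies within the scatter of both other compounds. Compound 4 `CC/C=C\C[C@H]1C(=O)C=C[C@H]1CC(=O)OC(C)COC` keeps the shared core but carries 1-(methoxymethyl)ethyl in place of 2-(2-methoxyethoxy)ethyl on an oxygen next to a carbonyl group. Three measured steps alter this same chain, and each of them is small: (a 1.1-fold higher number from compound 1 to compound 2 (0.03 log units; within the scatter)), (a 1.3-fold higher number from compound 1 to compound 3 (0.12 log units; within the scatter)) and (a 1.2-fold higher number from compound 2 to compound 3 (0.09 log units; within the scatter)). All three stay within the scatter. For the measured compounds named here, no measured compound carries 1-(methoxymethyl)ethyl, so that group itself remains untested. A step beyond the scatter in this assay is therefore not expected in either direction. The expected step (a 1.2-fold lower number from compound 3 to compound 4 (0.07 log units; within the scatter)) stays within the scatter. Compound 4 is estimated at 28000 nM with an expected range from 15000 nM to 50000 nM in this assay's terms.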

Compound 4, half-maximal effective concentration: 23000 nM
For compound 4 the middle estimate is 1.2-fold (0.09 log units) above the measured one; low and high end bracket the measured number.
By their numbers in this assay, from the lowest: compounds 4, 1, 2 and 3 (each within the scatter of the next).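

For the compounds shown here, with compound 4, a branch appears on the ester chain for the first time. In this assay, methyl in place of hydrogen on a saturated chain carbon bound to an oxygen next to a carbonyl group and a saturated chain carbon gives a 1.2-fold lower number from compound 2 to compound 4 (0.07 log units; within the scatter), so this branching stays within the scatter. On an oxygen next to a carbonyl group, 1-(methoxymethyl)ethyl in place of 2-(2-methoxyethoxy)ethyl gives a 1.4-fold lower number from compound 3 to compound 4 (0.16 log units; within the scatter), and in place of pentyl it gives a 1.1-fold lower number from compound 1 to compound 4 (0.04 log units; within the scatter), so this read-out separates none of the four chains, branched or unbranched.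

From the compounds shown here alone, whether a terminal amine, a carboxylic acid or a ring on this oxygen would give a step beyond the scatter stays open. Nothing available explains why these four numbers stay so close.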